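The source may report more compounds than this note shows. Statements on the series, on what has been measured and on what is new or still open speak of the compounds shown alone.

Measured compounds:
compound 1 `C#CCOc1ccc(-c2cc(-c3ccc(OCC#C)cc3)nc(N)n2)cc1` — 32100 nM
compound 2 `C#CCOc1ccc(-c2cc(-c3ccc(OCC#C)c(OC)c3)nc(-c3ccccc3)n2)cc1` — 24900 nM

In an assay on BTI-TN-5B1-4 cells for inhibition of Amine oxidase [flavin-containing] A (Homo sapiens), read by fluorescence and Amplex Red, using microsomes, with a stated time of 30 min (a higher number here means a weaker inhibitor, a lower number a stronger inhibitor), compound 2 gives 24900 nM, the lower of the two numbers. In this assay, among the measured compounds shown here, compound 1 gives 32100 nM; the gap to compound 2 lies within the scatter, so the two compounds are not distinguished by these numbers, and no step between them is recorded.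

Compound 3 `C#CCOc1ccc(-c2cc(-c3ccc(OCC#C)c(OC)c3)nc(N)n2)cc1` has not been measured. It differs from compound 2 by amino in place of phenyl on an aromatic carbon. For the measured compounds named here, the amino group it carries is the one found on compound 1, which in this assay gives 32100 nM, within the scatter of compound 2. On this basis no change beyond the scatter is expected. Compound 3 is expected to give 30000 nM, with a range of 12000 nM to 80000 nM. The expected step is a 1.2-fold higher number from compound 2 to compound 3 (0.08 log units; within the scatter), which is none beyond the scatter.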

Compound 3, half-maximal inhibitory concentration: "not active" (no number reported)
Compound 3 has no reported number here; there is nothing to compare the estimate with.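

Among the compounds shown here, compound 3 is reported as not active in this assay, without a number, and no step from compound 2 to compound 3 can be read. The compounds shown leave open whether amino in place of phenyl changes inhibition at all. Nothing available bears on this result.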